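The source may hold more compounds than are shown below. What is called first, only, known or untested is meant among the compounds shown, and "the series" means these compounds.

Series notes. Going by the values given here, compound 1 `COc1ccc(N(CC(=O)NCCC[Se]c2ccccc2)C(=O)c2ccccc2)cc1` gives 3.1 in a physicochemical assay for lipophilicity, read by HPLC, measured as octanol-water partition (on this read-out lower numbers stand for lower lipophilicity and higher numbers for higher lipophilicity), the lowest of the three numbers so far, though compound 2 sits within the scatter of it and only compound 3 lies beyond. Compound 2 `COc1ccc(N(CC(=O)NCCC[Se]c2ccccc2)C(=O)CNC(=O)OC(C)(C)C)cc1` gives 3.3 in this assay, and compound 3 `CC1=C(SCCC(=O)OCC(=O)NCCC[Te]c2ccccc2)C(=O)c2ccccc2C1=O` gives 3.8. Among the compounds with values here, the one step between neighbours that differ in a single place, a number 0.20 log units higher from compound 1 to compound 2 (within the scatter), falls within the scatter. Compound 4 `COc1ccc(N(CC(=O)NCCC[Te]c2ccccc2)C(=O)c2ccccc2)cc1` is not yet measured; it differs from compound 1 by a group of 7 heavy atoms (6 carbon, 1 tellurium; one six-membered aromatic ring of carbon only) in place of a group of 7 heavy atoms (6 carbon, 1 selenium; one six-membered aromatic ring of carbon only), on a saturated chain carbon, three bonds along the chain from an amide-type nitrogen. Within the data shown here, no measured step bears on this exchange. Among the measured compounds shown here, the only compound carrying tellurium is compound 3, and it differs from compound 1 in more than one place; the value of compound 3, 3.8, therefore shows only where a different core with tellurium lands, not the effect of the exchange alone. With nothing in the set to size the step, the expectation is a small move, if any, in this assay. The step from compound 1 to compound 4 is expected to be a number 0.20 log units higher from compound 1 to compound 4 (within the scatter). Compound 4 is estimated at 3.3, with a range from 2.9 to 3.7.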

Compound 4, partition coefficient: 1.72
Compound 4: the middle estimate sits 1.58 log units above what was measured, and the stated range ends above it.
By their numbers in this assay, from the lowest: compound 4; then compounds 1 and 2 (each within the scatter of the next); then compound 3.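

Working from the shared core, the exchange of the selenium-bearing group for the tellurium-bearing group, on a saturated chain carbon, three bonds along the chain from an amide-type nitrogen, gives in this assay a step of a number 1.38 log units lower from compound 1 to compound 4 (beyond the scatter) and so sets this position apart from the earlier single change, a number 0.20 log units higher from compound 1 to compound 2 (within the scatter). The entering and leaving groups match in heavy-atom count, ring, hydrogen-bond donors, hydrogen-bond acceptors and charge, and differ only in the one atom, so a change of that one atom at this position is enough for a large step in this read-out. Nothing at hand bears on the origin of this step.

As far as these compounds go, whether the same exchange on the core of compound 2 would give a step of similar size remains open. Also open, from the compounds shown here alone, is how an oxygen atom in the place of the selenium, or a longer chain carrying the tellurium-bearing group, would read.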